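Swapping One Aryl Group in a Cell-Growth Series

The source may hold more compounds than are shown below. What is called first, only, known or untested is meant among the compounds shown, and "the series" means these compounds.

In a functional assay on U-87MG ATCC cells for antiproliferative activity against U-87 MG (Homo sapiens), read by MTT assay, with a stated time of 48 h (on this read-out lower numbers stand for stronger inhibition and higher numbers for weaker inhibition), compound 1 (`Cc1nc(-c2ccc(Cl)cc2)sc1C(=O)CSc1nc(-c2ccccc2)c(C#N)c(=O)[nH]1`) gives 27600 nM and compound 2 (`COc1ccc(-c2nc(C)c(C(=O)CSc3nc(-c4ccc(Cl)cc4)c(C#N)c(=O)[nH]3)s2)cc1`) gives 45900 nM as its reading. Compound 2 holds the higher of these two numbers, but the gap lies within the usual scatter of repeated measurements, so the pair cannot be told apart on this evidence.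

The next molecule is compound 3 (`COc1ccc(-c2nc(C)c(C(=O)CSc3nc(-c4cccc(OC)c4)c(C#N)c(=O)[nH]3)s2)cc1`). It keeps the rest of compound 2 and carries 3-methoxyphenyl in place of 4-chlorophenyl on an aromatic carbon, ortho to a cyano group (3-methoxyphenyl in place of 4-chlorophenyl on an aromatic carbon). Within the data shown here, no two tested compounds differ in one place only, so the data offer no direct guide to the size of this swap. Compound 2 at 45900 nM is therefore the natural starting point, and no shift beyond the scatter is expected. The estimated change is a 1.3-fold lower number from compound 2 to compound 3 (0.12 log units; within the scatter) and it carries wide uncertainty. Compound 3 is expected at 35000 nM (estimated range 14000 nM to 90000 nM).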

Compound 3, half-maximal inhibitory concentration: 15300 nM
Beside the measured number, compound 3's estimate is 2.3-fold (0.36 log units) above it; low and high end bracket the measured number.
By their numbers in this assay, from the lowest: compounds 3, 1 and 2 (each within the scatter of the next, the first and the last beyond it).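

Among these compounds, this is the first pair that differs in one place only, so it gives the first direct reading of this position. In this assay the swap to 3-methoxyphenyl from 4-chlorophenyl, on the aromatic carbon ortho to a cyano group, brings a 3.0-fold lower number from compound 2 to compound 3 (0.48 log units; beyond the scatter) and shows that this position does respond to the group it carries, though the step is modest. The two earlier compounds could not show this since they differ in more than one place, and no measurement at hand accounts for the step.

The swap changes two things at once, the substituent on the phenyl ring and where it sits on that ring, so this single pair cannot say which of the two matters. Readings for 4-methoxyphenyl and 3-chlorophenyl at this position would pull those two apart, and a phenyl ring carrying an amine or a carboxylic acid would show whether the position accepts groups of a quite different kind.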